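A few compounds are considered here, and "the series" means these few. Any claim that something is new, unique, unknown or untested is made for them only; others in the source may bear on it.

Measured so far:
compound 1, `COc1ccc(C(=O)c2cc(OC)c(OC)c(OC)c2)cc1[N+](=O)[O-]`: > 10000 nM
compound 2, `COc1cc(C(=O)c2ccc3ccccc3c2)cc(OC)c1OC`: 250 nM

Compound 1 carries a nitro group on its core. In a functional assay on A549 cells (Homo sapiens) for cytotoxicity, read by XTT assay, with a stated time of 72 h (a lower number here means a stronger inhibitor, a higher number a weaker inhibitor), compound 1 gives > 10000 nM, which is a limit of the assay and not a number; compound 1 therefore sits at the limit of > 10000 nM in this assay, at which 1 of the 2 values shown sits, and its true value is not known. Compound 2 is the second measured compound, and in this assay compound 2 gives 250 nM. Going by the values given here, no pair of measured compounds differs in a single place, so no measured step is available, and the two values show only that one compound sits at the limit while the other gives a number well inside the measured range.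

Compound 3, `COc1ccc(C(=O)c2cc(OC)c(OC)c(OC)c2)cc1N`, has not yet been measured. It differs from compound 1 by amino in place of nitro on an aromatic carbon. Among the compounds with values here, with no measured step to lean on, the expectation rests on this change alone and carries a wide range. The estimate means a step of an at least 10-fold lower number from compound 1 to compound 3 (1.00 log units; beyond the scatter) in this assay, expected to run toward stronger inhibition and to exceed the usual scatter, though its size is uncertain. Compound 3 is expected to give about 1000 nM in this assay, with a range from 100 nM to 10000 nM.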

Compound 3, half-maximal inhibitory concentration: 57 nM
The estimate for compound 3 lay 18-fold (1.24 log units) above the measured number, outside the stated range (below it).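

Amino in place of nitro on an aromatic carbon, ortho to a methoxy group, gives an at least 170-fold lower number from compound 1 to compound 3 (2.24 log units; beyond the scatter) in this assay, the first step in the series that can be read from two compounds differing in one place. This single position therefore has a large bearing on the number in this assay: with the rest of the shared core unchanged, compound 3 gives 57 nM and lies well inside the measured range. From the compounds shown here alone, the true size of the step remains unknown and the printed figure is only a bound, because compound 1 stands at a limit of the assay and not at a number: the limit of > 10000 nM in this assay, at which 1 of the 3 values shown sits.

Whether the number of compound 3 is specific to amino remains open, as the compounds shown do not include a hydroxyl, a methylamino or an acetamide group at this position. Also open, going by these compounds, are whether a step of this size would recur on a different core and whether it would survive an ethoxy group in place of the methoxy group.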